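A few compounds are considered here, and "the series" means these few. Any claim that something is new, unique, unknown or untested is made for them only; others in the source may bear on it.

Values in an ADME assay on RAW264.7 cells (Mus musculus) for cytotoxicity, read by MTT assay, with a stated time of 24 h (a lower number here means a stronger inhibitor, a higher number a weaker inhibitor), for the measured compounds:

Compound 1 `O=C(S[C@@]12CC[C@H](O)[C@@H]1C(=O)NC2=O)c1ccccc1Cl` gives 668000 nM.
Compound 2 `O=C(S[C@@]12CC[C@H](O)[C@@H]1C(=O)NC2=O)c1ccccc1` gives 479000 nM.
Compound 3 `CC(=O)OC1CC[C@]2(SC(=O)c3ccccc3Cl)C(=O)NC(=O)[C@H]12` gives 9080000 nM.

Compounds 1 and 2 share a core and differ in one place, (hydrogen in place of chloro on an aromatic carbon). That change gave a 1.4-fold lower number from compound 1 to compound 2 (0.14 log units; within the scatter), so the two values cannot be told apart. Compound 3 has a different core; the difference between the two cores is not broken down here. Its value in this assay is the highest of the three, and its gaps to compound 1 and to compound 2 both lie beyond the scatter.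

Compound 4 `CC(=O)OC1CC[C@]2(SC(=O)c3ccccc3)C(=O)NC(=O)[C@H]12` has the core of compound 3 and differs from it by hydrogen in place of chloro on an aromatic carbon. The place of the change reads the same as for compound 1 to compound 2, so it is the same change seen a second time. The step it made before was within the scatter; the account therefore expects the step from compound 3 to compound 4 to be about as small, a 1.4-fold lower number from compound 3 to compound 4 (0.15 log units; within the scatter), resting on a 1.4-fold lower number from compound 1 to compound 2 (0.14 log units; within the scatter). Compound 4 is expected to give 6500000 nM in this assay, estimated between 2500000 nM and 16000000 nM.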

Compound 4, half-maximal inhibitory concentration: 1910000 nM
Compound 4: middle estimate off by 3.4-fold (0.53 log units), on the high side, outside the stated range (below it).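

In this assay, hydrogen in place of chloro on the aromatic carbon gave a 4.8-fold lower number from compound 3 to compound 4 (0.68 log units; beyond the scatter). The size of this step therefore did not carry over from one core to the other: the same change on two cores in this assay, a 1.4-fold lower number (0.14 log units; within the scatter) from compound 1 to compound 2 and a 4.8-fold lower number (0.68 log units; beyond the scatter) from compound 3 to compound 4, 3.4-fold (0.53 log units) apart, beyond the scatter of two such steps. Among the compounds shown here, this rests on only two pairs of compounds, so it shows that the step cannot be assumed to have the same size on both cores, but it does not show which feature of the cores accounts for the gap, or what size the step would take on a further core; since the step on the core of compound 1 lies within the scatter, the two pairs also cannot establish a shared direction.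

The compounds shown leave open how a fluoro group, a methoxy group or an amine in place of the chloro would read in this assay. They also leave open whether a longer chain on the ester of compound 3 and compound 4 would change the size of the step.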